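Adding a third methyl to the aryl thioether

The source may hold more compounds than are shown below. What is called first, only, known or untested is meant among the compounds shown, and "the series" means these compounds.

Three compounds share one core and differ only in the aromatic group that hangs from the sulfur. Compound 1 `CCOC(=O)c1c(CSc2ccc(OC)cc2)n(C)c2ccc(O)cc12` carries a 4-methoxyphenyl there, and in an assay for inhibition of Polyunsaturated fatty acid 5-lipoxygenase (Homo sapiens), read by HPLC, with a stated time of 10 min (a lower number here means a stronger inhibitor, a higher number a weaker inhibitor), compound 1 gives 2300 nM. Compound 2 `CCOC(=O)c1c(CSc2cccc(Cl)c2)n(C)c2ccc(O)cc12` carries a 3-chlorophenyl, and in this assay compound 2 gives 3800 nM; the change from the first to the second was a 1.7-fold higher number from compound 1 to compound 2 (0.22 log units; within the scatter). Compound 3 `CCOC(=O)c1c(CSc2c(C)cccc2C)n(C)c2ccc(O)cc12` carries a 2,6-dimethylphenyl, and in this assay compound 3 gives 800 nM, the lowest of the three numbers. The two changes that lead to it are a 2.9-fold lower number from compound 1 to compound 3 (0.46 log units; beyond the scatter) and a 4.8-fold lower number from compound 2 to compound 3 (0.68 log units; beyond the scatter).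

Compound 4 `CCOC(=O)c1c(CSc2c(C)cc(C)cc2C)n(C)c2ccc(O)cc12` keeps everything of compound 3 and differs in a single place: methyl in place of hydrogen on an aromatic carbon. Among the measured compounds shown here, both measured steps toward the 2,6-dimethylphenyl lowered the number, but each of them swapped the whole aromatic group, so no measured step shows what one further methyl alone does. On that basis the expected change in this assay is small, a 1.3-fold lower number from compound 3 to compound 4 (0.12 log units; within the scatter), leaning slightly toward a lower number. For compound 4 in this assay the estimate is 600 nM, with a range from 250 nM to 1500 nM.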

Compound 4, half-maximal inhibitory concentration: 700 nM
Compound 4: middle estimate off by 1.2-fold (0.07 log units), on the low side; the measured number falls inside the stated range.
By their numbers in this assay, from the lowest: compounds 4 and 3 (each within the scatter of the next); then compounds 1 and 2 (each within the scatter of the next).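

In this assay, among the compounds shown here, the change from 2,6-dimethylphenyl to 2,4,6-trimethylphenyl is the first step here that adds one methyl and alters nothing else, and it leaves the two compounds indistinguishable (a 1.1-fold lower number from compound 3 to compound 4 (0.06 log units; within the scatter)). So the place meta to two methyl groups and para to a large group can carry this extra methyl with no change that stands out from the scatter, and the advantage over the other two aromatic groups remains, both against the 3-chlorophenyl (a 5.4-fold lower number from compound 2 to compound 4 (0.73 log units; beyond the scatter)) and against the 4-methoxyphenyl (a 3.3-fold lower number from compound 1 to compound 4 (0.52 log units; beyond the scatter)). No supporting data are available to explain why this added methyl makes so little difference.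

The compounds shown leave open how a longer chain, an amine or a carboxylic acid would behave at this same place with the two methyl groups kept. For the compounds shown here, they also leave open what each of those two methyl groups contributes on its own, as no pair here differs by just one of them.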